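Removing One Methyl Group from a Dimethylbenzyl Side Chain

A few compounds are considered here, and "the series" means these few. Any claim that something is new, unique, unknown or untested is made for them only; others in the source may bear on it.

Compound 1, `N[C@H](C(=O)O)C(Cc1ccccc1)C(=O)O`: 4%
Compound 2, `N[C@H](C(=O)O)C(Cc1ccc2ccccc2c1)C(=O)O`: 68%
Compound 3, `Cc1cc(C)cc(CC(C(=O)O)[C@H](N)C(=O)O)c1`: 36%

Of the compounds shown here, three sharing one amino-acid core have been tested in an in vitro assay on cells for inhibition of excitatory amino acid transporter 3 (Homo sapiens), tested at 100 uM; a lower number here means less inhibition, a higher number more inhibition at the concentration tested (going by the name of the read-out). Compound 1, with a plain benzyl side chain, gives 4%. Compound 2, whose side chain carries a naphthyl group, gives 68%. Compound 3, with two methyl groups on the benzyl ring, gives 36% and so stands second highest of the three, lying beyond the usual scatter from both compound 1 below it and compound 2 above it.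

Compound 4, `Cc1cccc(CC(C(=O)O)[C@H](N)C(=O)O)c1`, is not yet measured. It differs from compound 3 by hydrogen in place of methyl on an aromatic carbon.

Since compound 1, with no methyl group at all, gives 4%, and compound 3, with two methyl groups, gives 36%, compound 4 with a single methyl group is expected to fall between them, meaning a step of a number 16 percentage points lower from compound 3 to compound 4 (beyond the scatter) downward in this assay. For compound 4 the estimated value is 20%, with a range from 5% to 40%.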

Compound 4, a percentage reported as inhibition, at one concentration (the size of the read-out at that concentration, not a potency): 33%
Compound 4: the middle estimate sits 13 percentage points below what was measured, and the stated range covers the measured number.
By their numbers in this assay, from the lowest: compound 1; then compounds 4 and 3 (each within the scatter of the next); then compound 2.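

In this assay, replacing one methyl group of compound 3 with hydrogen gives a number 3 percentage points lower from compound 3 to compound 4 (within the scatter), so at this aromatic carbon the second methyl group adds nothing that can be told apart from the scatter. Compound 4 also shows that a single methyl group on the ring of compound 1 is enough for a clear change, with a number 29 percentage points higher from compound 1 to compound 4 (beyond the scatter) as the step. No measurement shown offers a reason for this difference between the two methyl changes.

The compounds shown leave open whether a larger or different group at the remaining methyl position, such as an ethyl group, a methoxy group or a chlorine atom, would do the same or more. They also leave open whether a single methyl group on another carbon of the ring would give a similar number.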